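The source may hold more compounds than are shown below. What is called first, only, known or untested is meant among the compounds shown, and "the series" means these compounds.

Of the compounds shown here, three have been measured in a functional assay, read by Griess assay, with a stated time of 150 min, tested at 100 ug/mL; a higher number here means a stronger effect of the compound at the concentration tested, a lower number a weaker effect. Compound 1 `COc1ccc(-c2noc(-c3ccc(C)cc3)c2S(=O)(=O)CC2=NCCO2)cc1` gives 76.2%. Compound 2 `O=S(=O)(CC1=NCCO1)C1C(c2ccccc2)=NOC1c1ccccc1` gives 62.8%, the lowest of the two numbers reported, and compound 1 stands above it by a gap beyond the usual scatter. Compound 3 `O=S(=O)(CC1=NCCS1)C1=NNCC1c1ccc(Cl)cc1` is reported as "not active" (no number reported), with no number attached.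

Compound 4 `O=S(=O)(CC1=NCCS1)C1C(c2ccccc2)=NOC1c1ccccc1` has not yet been measured. It differs from compound 2 in one place:

a group of 5 heavy atoms (3 carbon, 1 nitrogen, 1 sulfur; one five-membered non-aromatic ring with 2 hetero atoms) in place of a group of 5 heavy atoms (3 carbon, 1 nitrogen, 1 oxygen; one five-membered non-aromatic ring with 2 hetero atoms), on a saturated chain carbon bound to a sulfonyl sulfur

Among the measured compounds shown here, no measured pair shows this change on the shared core, so its size cannot be read from a step already seen. Compound 3 carries the entering group on a different core and is reported as "not active" (no number reported), which speaks against a gain from this swap. The step from compound 2 to compound 4 is expected to be modest and downward, if anything, at a number 7.8 percentage points lower from compound 2 to compound 4 (within the scatter), and it may well stay within the scatter. Compound 4 is therefore estimated at 55%, within a range from 35% to 72%.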

Compound 4, a percentage reported as activity, at one concentration (the size of the read-out at that concentration, not a potency): "not active" (no number reported)
Compound 4: no number reported, so the estimate cannot be set against anything.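

Among the compounds shown here, compound 4 carries no number in this assay, so no step from compound 2 to compound 4 can be read. Nothing shown bears on the reason for this result. The compounds shown leave open what size the exchange of these two five-membered rings has on this shared core.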